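Dropping a Chloro Group: Cytotoxicity in Kidney Cells

A few compounds are considered here, and "the series" means these few. Any claim that something is new, unique, unknown or untested is made for them only; others in the source may bear on it.

Measured so far:
compound 1, `Clc1cccc(C2=NOC(c3ccc(Cl)c(Cl)c3)O2)c1`: > 100000 nM
compound 2, `Clc1ccc(C2ON=C(c3cccc(Cl)c3)O2)cc1`: > 100000 nM
compound 3, `Clc1ccc(C2=NOC(c3ccc(Cl)c(Cl)c3)O2)cc1`: > 100000 nM

In an ADME assay on HEK293 cells (Homo sapiens) for cytotoxicity, read by MTT assay, with a stated time of 44 h (a lower number here means a stronger inhibitor, a higher number a weaker inhibitor), compound 1 reaches only a limit of the assay, > 100000 nM. Compound 2 likewise gives a limit, > 100000 nM, and compound 3 gives a limit, > 100000 nM. Compound 1 and compound 2 differ by hydrogen in place of chloro on an aromatic carbon, and that step, a step that the two limits leave unreadable from compound 1 to compound 2, cannot be read because both values sit at the limit of > 100000 nM in this assay, at which 3 of the 3 values shown sit. The same kind of change, (hydrogen in place of chloro on an aromatic carbon), leads from compound 3 to the still unmeasured compound 4, `Clc1ccc(C2=NOC(c3ccc(Cl)cc3)O2)cc1`. The cores of compound 1 and compound 3 share the same atoms joined differently, a difference not broken down here. Since all three measured values rest at the limit of > 100000 nM in this assay, at which 3 of the 3 values shown sit, compound 4 is expected to stay near that limit, with an estimated step of a number no higher from compound 3 to compound 4 (the limit leaves the size open). The expected value for compound 4 is 100000 nM, between 30000 nM and 300000 nM.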

Compound 4, half-maximal inhibitory concentration: > 100000 nM
Compound 4 ended at the assay's limit; the forecaster's own chance of this, stated with the estimate: 85%; the middle value sits exactly at the limit.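

Compound 4 gives only a limit of the assay, > 100000 nM. The step from compound 3 to compound 4 therefore cannot be read, as every value sits at one limit: the limit of > 100000 nM in this assay, at which 4 of the 4 values shown sit. The compounds shown leave open what concentration, if any, would give half-maximal inhibition in this assay.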